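A few compounds are considered here, and "the series" means these few. Any claim that something is new, unique, unknown or untested is made for them only; others in the source may bear on it.

Measured in an ADME assay on microsomes from liver (Rattus norvegicus) for metabolic stability; on this read-out lower numbers stand for a shorter-lived compound and higher numbers for a longer-lived compound:
- compound 1 `CC#C[C@@H](Cc1nnn[nH]1)c1ccc(OCc2ccc3sc(F)c(-c4ccccc4C)c3c2)cc1`: 0.367 h
- compound 2 `CC#C[C@@H](Cc1nnn[nH]1)c1ccc(OCc2ccc3scc(-c4ccc(OCCCS(C)(=O)=O)cc4C)c3c2)cc1`: 1.48 h
- compound 3 `CC#C[C@@H](Cc1nnn[nH]1)c1ccc(OCc2ccc3sc(C)c(-c4ccc(OCCOC)cc4C)c3c2)cc1`: 0.117 h

Compound 2 stands highest of the three numbers. Compound 1 is nearest to it and compound 3 furthest, and both gaps lie beyond the usual scatter.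

Compound 4 `CC#C[C@@H](Cc1nnn[nH]1)c1ccc(OCc2ccc3scc(-c4ccc(OCCOC)cc4C)c3c2)cc1` is not yet measured. It differs from compound 2 by methoxy in place of (methylsulfonyl)methyl on a saturated chain carbon, two bonds along the chain from an oxygen on an aromatic ring. The same difference reads 3-(methylsulfonyl)propoxy to 2-methoxyethoxy.

For the measured compounds named here, no pair of measured compounds isolates this change, so any expectation is indirect. Compound 3 also carries 2-methoxyethoxy, though its core is not that of compound 4, and compound 3 gives 0.117 h. A move to a shorter half-life in this assay, beyond the scatter, is expected on that single comparison. The expected change is a 4.2-fold lower number from compound 2 to compound 4 (0.63 log units; beyond the scatter). In this assay, the estimated value for compound 4 is 0.35 h, with an expected range of 0.12 h to 1 h.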

Compound 4, half-life: 0.217 h
For compound 4 the middle estimate is 1.6-fold (0.21 log units) above the measured one, within the range that was stated.
By their numbers in this assay, from the lowest: compounds 3, 4 and 1 (each within the scatter of the next, the first and the last beyond it); then compound 2.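

In this assay, the swap from 3-(methylsulfonyl)propoxy to 2-methoxyethoxy now has a direct reading on a shared core: a 6.8-fold lower number from compound 2 to compound 4 (0.83 log units; beyond the scatter) shows that the longer-lived side of this small set depends on the group at this position. With 2-methoxyethoxy held constant, hydrogen in place of methyl on an aromatic carbon gives a 1.9-fold higher number from compound 3 to compound 4 (0.27 log units; within the scatter) and so cannot be separated from the scatter on this read-out. No supporting measurement accounts for the size of the chain step.

A single pair cannot separate the methylsulfonyl group from chain length, and a 3-methoxypropoxy or 2-(methylsulfonyl)ethoxy chain would pull these apart. As far as these compounds go, whether an amine or a carboxylic acid at the end of the chain would fall near compound 2 or compound 4 also remains open.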